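A few compounds are considered here, and "the series" means these few. Any claim that something is new, unique, unknown or untested is made for them only; others in the source may bear on it.

Three measured compounds share one core. Compound 1 `C#CCNC1CCc2c(SCc3cccc(OC)c3)cccc21` gives 3190 nM in an assay on isolated protein for inhibition of Amine oxidase [flavin-containing] B (Homo sapiens) (a lower number here means a stronger inhibitor, a higher number a weaker inhibitor), and compound 3 `C#CCNC1CCc2c(SCc3ccc(F)cc3F)cccc21` gives 2430 nM in this assay. Compound 2 `C#CCNC1CCc2c(SCc3cccc(Cl)c3)cccc21` gives 23300 nM in this assay, the highest of the three numbers and the weakest inhibitor of the set. Going by the values given here, the only single-point step measured, a 7.3-fold higher number from compound 1 to compound 2 (0.86 log units; beyond the scatter), lies beyond the scatter. Compound 4 `C#CCNC1CCc2c(SCc3ccc(Br)cc3)cccc21` differs from compound 2 by 4-bromophenyl in place of 3-chlorophenyl on a saturated chain carbon bound to a sulfur. Among the compounds with values here, no measured step swaps one halogen for another on that ring, so the step from compound 1 to compound 2 bears on it only loosely; compound 3 shows a different halogen pattern on that ring giving a lower number. For compound 4 the expected step is a 2.6-fold lower number from compound 2 to compound 4 (0.41 log units; beyond the scatter), with its direction uncertain. Compound 4 is estimated at 9000 nM, between 2500 nM and 30000 nM.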

Compound 4, half-maximal inhibitory concentration: 1310 nM
The estimate for compound 4 lay 6.9-fold (0.84 log units) above the measured number; measured number outside the range, below it.
By their numbers in this assay, from the lowest: compounds 4, 3 and 1 (each within the scatter of the next, the first and the last beyond it); then compound 2.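

Replacing 3-chlorophenyl with 4-bromophenyl on the saturated chain carbon bound to a sulfur gives an 18-fold lower number from compound 2 to compound 4 (1.25 log units; beyond the scatter), a large step in the opposite direction to the earlier 7.3-fold higher number from compound 1 to compound 2 (0.86 log units; beyond the scatter). This position can therefore carry a change that moves compound 2 well out of its place as the weakest inhibitor of the set. No available evidence explains this step. The halogen and its place on the ring change together, and the compounds shown do not separate the two. As far as these compounds go, how 4-chlorophenyl or 3-bromophenyl would read at this position remains open.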